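Trifluoromethyl to fluoro on two related cores

The source may hold more compounds than are shown below. What is called first, only, known or untested is meant among the compounds shown, and "the series" means these compounds.

The series holds two cores. Compound 2 `CN1C/C(=C\c2cccnc2)C(=O)/C(=C/c2ccccc2C(F)(F)F)C1` and compound 1 `CN1C/C(=C\c2cccnc2)C(=O)/C(=C/c2ccccc2F)C1` share the first; compound 3 `O=C1/C(=C/c2ccncc2)CN(S(=O)(=O)c2ccc(C(F)(F)F)cc2)C/C1=C\c1ccccc1F` and compound 4 `O=C1/C(=C/c2ccncc2)CN(S(=O)(=O)c2ccc(F)cc2)C/C1=C\c1ccccc1F` share the second. The difference between the two cores is not broken down here.

In a functional assay on SMMC-7721 cells (Homo sapiens) for cytotoxicity, read by MTT assay, with a stated time of 24 h (a lower number here means a stronger inhibitor, a higher number a weaker inhibitor), compound 2 gives 3900 nM and compound 1 gives 5420 nM. The change between them, (fluoro in place of trifluoromethyl on an aromatic carbon), reads as a 1.4-fold higher number from compound 2 to compound 1 (0.14 log units; within the scatter), so the two numbers cannot be told apart.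

In this assay compound 3 gives 11100 nM. Compound 3 stands highest of the three measured compounds, and its distance from both compound 1 and compound 2 lies beyond the scatter.

Compound 4 differs from compound 3 by fluoro in place of trifluoromethyl on an aromatic carbon. For the measured compounds named here, this is the same kind of change as the one between compound 2 and compound 1, but not the same change: there the group sits ortho to a large group, here it sits para to a large group, and the two cores are not the same either.

Going by the values given here, for compound 4 the step of a 1.2-fold higher number from compound 3 to compound 4 (0.07 log units; within the scatter) is expected, because the only measured instance of this kind of change, a 1.4-fold higher number from compound 2 to compound 1 (0.14 log units; within the scatter), stayed within the scatter. Among the compounds with values here, no other pair tests it. Compound 4 is therefore estimated at 13000 nM in this assay, with the likely range running from 6000 nM to 30000 nM.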

Compound 4, half-maximal inhibitory concentration: > 20000 nM
Compound 4: a limit, no number; the forecaster's own chance of this, stated with the estimate: 15%; at least 1.5-fold (0.18 log units) between middle value and limit.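

In this assay compound 4 gives > 20000 nM, which is a limit of the assay and not a number, and no other compound in the series sits there: the limit of > 20000 nM in this assay, at which 1 of the 4 values shown sits.

Fluoro in place of trifluoromethyl on the core of compound 3 gives an at least 1.8-fold higher number from compound 3 to compound 4 (0.25 log units; that floor lies within the scatter), and set beside the same change on the other core, the comparison reads: the same change on two cores in this assay, a 1.4-fold higher number (0.14 log units; within the scatter) from compound 2 to compound 1 and an at least 1.8-fold higher number (0.25 log units; that floor lies within the scatter) from compound 3 to compound 4; the limit leaves it open whether they differ

The step on the core of compound 2 cannot be told from the scatter, and the floor of the step on the core of compound 3 also lies within it, so the two cores show no conflict over this change. They do not show that the change carries over with the same size, since the second step has only a floor and each core offers a single pair.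

The compounds shown leave open whether chloro, methoxy or a nitrile in place of the trifluoromethyl on the core of compound 3 would give a value that is a number rather than a limit. For the compounds shown here, no pair here separates the difference between the two cores from the change itself, so that difference also stays open.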